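Toward the pyridin-3-yl amide in the FaDu series

The source may report more compounds than this note shows. Statements on the series, on what has been measured and on what is new or still open speak of the compounds shown alone.

Values in a functional assay on FaDu cells (Homo sapiens) for cytotoxicity, read by MTT assay, with a stated time of 72 h; on this read-out higher numbers stand for lower toxicity in this test and lower numbers for higher toxicity in this test:
- compound 1 `COc1ccc(NC(=O)C(=O)c2cn(C(C)C)c3ccccc23)cc1`: 181 nM
- compound 2 `COc1ccc(NC(=O)C(=O)c2cn(C(C)C)c3cccc(OC)c23)cn1`: 7780 nM

Of these two measured compounds, compound 1 has the lower number, and its gap to compound 2 lies beyond the scatter. Compound 1 is therefore the more toxic of the pair in this assay.

The next compound is compound 3 `CC(C)n1cc(C(=O)C(=O)Nc2cccnc2)c2ccccc21`, which carries pyridin-3-yl in place of 4-methoxyphenyl on an amide-type nitrogen.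

Within the data shown here, no measured pair isolates this change, so the step has no direct precedent. Compound 1 and compound 2 differ in more than one place, so the higher value of compound 2, 7780 nM, offers only loose guidance. It does, however, favour a move toward lower toxicity over a move toward higher toxicity, and a step beyond the scatter is expected in that direction. The expected step is an 8.3-fold higher number from compound 1 to compound 3 (0.92 log units; beyond the scatter). For compound 3 the estimated value is 1500 nM, with an expected range of 280 nM to 8000 nM.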

Compound 3, concentration lethal to 50% of the cells: > 10000 nM
Compound 3 gave a limit, no number; the forecaster's own chance of this, stated with the estimate: 10%; middle value at least 6.6-fold (0.82 log units) away from the limit.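

Among these compounds, for the first time, one change is isolated: pyridin-3-yl in place of 4-methoxyphenyl on an amide-type nitrogen, whose other neighbour is the carbonyl carbon, gives an at least 55-fold higher number from compound 1 to compound 3 (1.74 log units; beyond the scatter) in this assay. The toxicity of compound 1 in this test therefore depends strongly on the group at this place, which the comparison of compound 1 with compound 2, differing in more than one place, could not show. The entry for compound 3 is a limit of the assay and not a number, so the step gives only a bound on the size of the change: the limit of > 10000 nM in this assay, at which 1 of the 3 values shown sits.

The compounds shown do not separate the effect of the ring nitrogen in pyridin-3-yl from that of losing the methoxy group, and a plain phenyl on the same amide-type nitrogen would address that question directly. Also open, from the compounds shown here alone, is how an aminophenyl or a carboxyphenyl would read at this place in this assay, and whether any ring with a hetero atom here can give a value that is a number rather than a limit.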